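Swapping a methoxynaphthyl arm for a hydroxyphenyl one

This account rests on a few compounds, and the source may have more. Where it says the series, first, only, none or still open, it means among the compounds named here.

Compound 1 `COc1cc(N2C(N)=C(C#N)C(c3ccc([N+](=O)[O-])cc3)C3=C2CC(C)(C)CC3=O)cc(OC)c1OC`: 25000 nM
Compound 2 `COc1cc(N2C(N)=C(C#N)C(c3c(OC)ccc4ccccc34)C3=C2CC(C)(C)CC3=O)cc(OC)c1OC`: "not active" (no number reported)

In a functional assay on Ehrlich cells (Mus musculus) for cytotoxicity (on this read-out lower numbers stand for stronger inhibition and higher numbers for weaker inhibition), compound 1 gives 25000 nM, a weak result. Compound 2 was reported as "not active" (no number reported) in this assay, with no number given, so its standing cannot be put on a scale. Compound 3 `COc1cc(N2C(N)=C(C#N)C(c3ccccc3O)C3=C2CC(C)(C)CC3=O)cc(OC)c1OC` is not yet measured. It differs from compound 2 in one place: 2-hydroxyphenyl in place of 2-methoxynaphthalen-1-yl on a saturated ring carbon. Within the data shown here, with no measured step to lean on, the direction of the change is open; the shared core gave only weak or no inhibition in both measured compounds. Compound 3 is therefore expected to be weak too, estimated at 30000 nM, within 8000 nM to 100000 nM.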

Compound 3, half-maximal inhibitory concentration: "not active" (no number reported)
Compound 3: no number reported; no gap can be computed for the estimate.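

Compound 2 and compound 3 were both reported without a number, and no step can be read between them. No measurement shown explains this result. On these data alone, how far apart the 2-methoxynaphthalen-1-yl and 2-hydroxyphenyl compounds truly stand remains open.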